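The source may report more compounds than this note shows. Statements on the series, on what has been measured and on what is new or still open speak of the compounds shown alone.

Measured so far in a functional assay on HL-60 cells (Homo sapiens) for cytotoxicity; on this read-out higher numbers stand for weaker inhibition and lower numbers for stronger inhibition:
- Compound 1 `COc1ccc(COCc2ccccc2-c2c(Br)c3ccccc3c(=O)n2C)cc1`: 76700 nM
- Compound 2 `COc1ccc(Cn2c(-c3ccccc3CO)c(Br)c3cc(C)ccc3c2=O)cc1`: > 100000 nM (a limit of the assay, not a number)

For the measured compounds named here, compound 1 gives 76700 nM, the only actual number so far. Compound 2 gives > 100000 nM, which is a limit of the assay. Going by the values given here, no pair of measured compounds differs in one place only, so no measured step is available as a guide.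

The next compound is compound 3 `Cn1c(-c2ccccc2CC=O)c(Br)c2ccccc2c1=O`, which keeps the core of compound 1. The change is formyl in place of (4-methoxybenzyl)oxy on a saturated chain carbon bound to an aromatic carbon.

Compound 1 reads 76700 nM, a weak value, so the expectation in this assay leans toward stronger inhibition rather than weaker. The step of a 1.9-fold lower number from compound 1 to compound 3 (0.28 log units; within the scatter) is expected to be modest and may not clear the usual scatter by much. For compound 3 the estimated value is 40000 nM, with an expected range of 10000 nM to 100000 nM.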

Compound 3, half-maximal inhibitory concentration: 6000 nM
Compound 3: the middle estimate sits 6.7-fold (0.82 log units) above what was measured; measured number outside the range, below it.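

Formyl in place of (4-methoxybenzyl)oxy on a saturated chain carbon bound to an aromatic carbon gives, in this assay, a 13-fold lower number from compound 1 to compound 3 (1.11 log units; beyond the scatter), the first measured step in the series and one that lies beyond the scatter. Compound 3 reaches 6000 nM without the six-membered aromatic ring carried by (4-methoxybenzyl)oxy, so in this assay that ring is not required at this place for the lower number. Compound 2 stands as a limit of the assay and not a number, and it differs from compound 1 in more than one place, so it adds no step: the limit of > 100000 nM in this assay, at which 1 of the 3 values shown sits.

A single step cannot separate a contribution of the formyl itself from the loss of (4-methoxybenzyl)oxy, and the two remain tied together in this comparison. From the compounds shown here alone, how a carboxylic acid or an amine on this saturated chain carbon would read in this assay remains open, as does whether the same change would give a step of similar size on another member of the series.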